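Ester for Amide: Cytotoxicity Outlook on a Shared Core

The compounds below may be only part of what the source reports. "The series", "measured", "known", "first", "only" and "open" are said of these compounds alone.

Measured so far:
Compound 1, `COC[C@H]1C[C@@](CC(C)C)(C(=O)O)N(C(=O)c2ccc(C(C)(C)C)c(OC)c2)[C@@H]1c1nccs1`, gives 200000 nM in an ADME assay on Huh-5-2 cells (Homo sapiens) for cytotoxicity, with a stated time of 3 days; on this read-out higher numbers stand for lower toxicity in this test and lower numbers for higher toxicity in this test.
Compound 2, `COC[C@H]1C[C@@](CC(C)C)(C(=O)O)N(C(=O)c2ccc(C(C)(C)C)c(OC)c2)[C@H]1[C@H]1COC(C)(C)O1`, gives > 120000 nM in this assay, which is a limit of the assay rather than a number.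
Compound 3, `COC[C@H]1C[C@@](CC(C)C)(C(=O)O)N(C(=O)c2ccc(C(C)(C)C)c(OC)c2)[C@H]1C(N)=O`, gives > 120000 nM in this assay, again only a limit.

Compound 3 therefore stands at the upper edge of what this assay can report, and it shares that position with compound 2, as the limit of > 120000 nM in this assay, at which 2 of the 3 values shown sit, shows, while compound 1 alone gives a readable number. Among the measured compounds shown here, the single step between neighbouring compounds, a step that the two limits leave unreadable from compound 2 to compound 3, is left unreadable by the two limits, so no measured step gives a size for comparison.

Compound 4, `COC[C@H]1C[C@@](CC(C)C)(C(=O)O)N(C(=O)c2ccc(C(C)(C)C)c(OC)c2)[C@H]1C(=O)OC`, differs from compound 3 by methoxy in place of amino on a carbonyl carbon. Nothing measured here bears on this change, so no step beyond the usual scatter is expected in either direction. Compound 4 is expected to give about 150000 nM in this assay, within a range from 60000 nM to 300000 nM. The expected step that the limit leaves unreadable from compound 3 to compound 4 is thus estimated to stay inside the scatter, and a reported limit rather than a number remains likely.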

Compound 4, half-maximal cytotoxic concentration: > 120000 nM
Compound 4 ended at the assay's limit (the forecaster's own chance of this, stated with the estimate: 60%); the middle value is on the limit's open side.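

Compound 2, compound 3 and compound 4 all end at the same limit rather than at a number, so no step among them can be read: the limit of > 120000 nM in this assay, at which 3 of the 4 values shown sit.

The compounds shown leave open how far each of these three lies past that limit in this assay, and whether carbamoyl and methoxycarbonyl differ there at all.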